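Urea aryl variation on the piperazine-bearing core

The source may hold more compounds than are shown below. What is called first, only, known or untested is meant among the compounds shown, and "the series" means these compounds.

Measured compounds:
compound 1 `C=CS(=O)(=O)N1CCN(c2nc(OC[C@H]3CCCN3C)nc3sc(-c4ccc(N5CCN(C)CC5)cc4)cc23)[C@@H](C)C1` — 1920 nM
compound 2 `CN1CCN(c2ccc(-c3cc4c(N5CCN(S(=O)(=O)C6CC6)CC5)ncnc4s3)cc2)CC1` — 10600 nM
compound 3 `COc1ccc(NC(=O)N2CCN(c3ncnc4sc(-c5ccc(N6CCN(C)CC6)cc5)cc34)CC2)cc1` — 30100 nM

In a functional assay on MDA-MB-436 cells (Homo sapiens) for antiproliferative activity, read by MTT assay, with a stated time of 48 h (a lower number here means a stronger inhibitor, a higher number a weaker inhibitor), compound 3 gives 30100 nM, the highest number of the three. Compound 2 gives 10600 nM and compound 1 gives 1920 nM; the step of a 2.8-fold higher number from compound 2 to compound 3 (0.45 log units; beyond the scatter) comes with the (4-methoxyphenyl)carbamoyl in place of cyclopropylsulfonyl on an amine nitrogen in a ring.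

Compound 4 `CC(C)c1cccc(C(C)C)c1NC(=O)N1CCN(c2ncnc3sc(-c4ccc(N5CCN(C)CC5)cc4)cc23)CC1` is not yet measured. It differs from compound 3 by 2,6-diisopropylphenyl in place of 4-methoxyphenyl on an amide-type nitrogen. Within the data shown here, no measured step changes the aryl group on the amide-type nitrogen; the single step from compound 2 to compound 3 alters the whole substituent on the ring nitrogen and does not bear directly on this change. With nothing comparable among the measured compounds, the expectation is a step of no more than modest size in this assay, with no firm direction.

Compound 4 is therefore estimated at 35000 nM (range 12000 nM to 100000 nM), which means an expected step of a 1.2-fold higher number from compound 3 to compound 4 (0.07 log units; within the scatter).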

Compound 4, half-maximal inhibitory concentration: 11300 nM
Estimate against measurement, compound 4: 3.1-fold (0.49 log units) above; the whole stated range lies above it.
By their numbers in this assay, from the lowest: compound 1; then compounds 2 and 4 (each within the scatter of the next); then compound 3.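

In this assay, among these compounds, the aryl group on the amide-type nitrogen proves able to move the number: there is a 2.7-fold lower number from compound 3 to compound 4 (0.43 log units; beyond the scatter), with 2,6-diisopropylphenyl in place of 4-methoxyphenyl, the first change confined to this aryl group. The urea itself therefore does not fix the number, since compound 4 gives 11300 nM and compound 2 gives 10600 nM, values within the scatter of each other even though the substituent on the ring nitrogen differs. No measurement at hand accounts for the step.

With one pair, the loss of the methoxy group and the arrival of the two isopropyl groups cannot be separated; a plain phenyl or a 2,6-dimethylphenyl on the same nitrogen would help to do so. Also open, as far as these compounds go, is how an aryl group carrying an amine or a carboxylic acid would behave here.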